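Cinnamate ester series: isobutyl to 2,2,2-trichloroethyl

This account rests on a few compounds, and the source may have more. Where it says the series, first, only, none or still open, it means among the compounds named here.

Compound 3 `CCOc1cc(NC(=O)C2(NC(=O)c3ccc4c(C5CCCC5)c(-c5ncc(Cl)cn5)n(C)c4c3)CCC2)ccc1/C=C/C(=O)OCC(C)C` in an ADME assay (intestine, Rattus norvegicus) for pharmacokinetics, using microsomes (a lower number here means that the compound disappears faster, a higher number that the compound lasts longer), gives > 5 h, which is a limit of the assay rather than a number. Compound 2 `CCCOC(=O)/C=C/c1ccc(NC(=O)C2(NC(=O)c3ccc4c(C5CCCC5)c(-c5ncc(Cl)cn5)n(C)c4c3)CCC2)cc1OCC` likewise sits at the limit > 5 h. Compound 1 `CCOc1cc(NC(=O)C2(NC(=O)c3ccc4c(C5CCCC5)c(-c5ncc(Cl)cn5)n(C)c4c3)CCC2)ccc1/C=C/C(=O)OCOP(=O)(O)O` gives 0.0833 h. The two readable steps are an at least 60-fold higher number from compound 1 to compound 3 (1.77 log units; beyond the scatter) and an at least 60-fold higher number from compound 1 to compound 2 (1.77 log units; beyond the scatter); the step that the two limits leave unreadable from compound 2 to compound 3 is not readable, as the limit of > 5 h in this assay, at which 2 of the 3 values shown sit, shows. Compound 4 `CCOc1cc(NC(=O)C2(NC(=O)c3ccc4c(C5CCCC5)c(-c5ncc(Cl)cn5)n(C)c4c3)CCC2)ccc1/C=C/C(=O)OCC(Cl)(Cl)Cl` differs from compound 3 by trichloromethyl in place of isopropyl on a saturated chain carbon bound to an oxygen next to a carbonyl group. Going by the values given here, none of the measured steps changes the ester alcohol between two alkyl groups, so they give no direct guide. For compound 4 the step of an at least 2.5-fold lower number from compound 3 to compound 4 (0.39 log units; beyond the scatter) is expected to fall below the limit. The estimate for compound 4 in this assay is 2 h, within 0.5 h to 5 h.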

Compound 4, half-life: > 5 h
Compound 4: only a limit was reported; the forecaster's own chance of this, stated with the estimate: 35%; at least 2.5-fold (0.39 log units) between middle value and limit.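

With trichloromethyl on this saturated chain carbon, the ester stays as long-lived as the alkyl esters in this assay: an at least 60-fold higher number from compound 1 to compound 4 (1.77 log units; beyond the scatter), so the large step from compound 1 is not confined to alkyl groups. For compound 4 the value is a limit of the assay and not a number. The steps from compound 2 and compound 3 to compound 4 cannot be read, because all three stop at the same limit: the limit of > 5 h in this assay, at which 3 of the 4 values shown sit.

On these data alone, how far these esters differ in this assay stays open. Nor do the compounds shown tell how a benzyl ester, an ester carrying an amine, or the free carboxylic acid would behave.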